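The source may report more compounds than this note shows. Statements on the series, on what has been measured and on what is new or still open speak of the compounds shown alone.

Compound 1 `COc1ccc(C(O)C2OC(=O)c3c(OC)cc(OC)cc32)cc1`: > 10000 nM
Compound 2 `CCOc1ccc(C(O)C2OC(=O)c3c(OC)cc(OC)cc32)cc1`: > 10000 nM
Compound 3 `COc1cc(OC)c2c(c1)C(C(O)c1ccc(OCc3ccc(C)cc3)cc1)OC2=O`: 3120 nM

In a functional assay on RAW264.7 cells (Mus musculus) for inhibition, read by Griess assay, with stated times of 1 h and 24 h (a higher number here means a weaker inhibitor, a lower number a stronger inhibitor), compound 1 gives > 10000 nM, which is a limit of the assay rather than a number. Compound 2 likewise gives only a limit, > 10000 nM. Compound 3 gives a measured number, 3120 nM. Compound 1 therefore stands at the limit, with no exact value, and two of the three results sit at that same limit (the limit of > 10000 nM in this assay, at which 2 of the 3 values shown sit).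

The step of interest leads from compound 1 to compound 4 `COc1cc(OC)c2c(c1)C(C(O)c1ccc(OCC3CCCCC3)cc1)OC2=O`: cyclohexyl in place of hydrogen on a saturated chain carbon bound to an oxygen on an aromatic ring. The change from compound 1 to compound 2 is a step that the two limits leave unreadable from compound 1 to compound 2, so it says nothing about size. Within the data shown here, the steps that bear on the new change are an at least 3.2-fold lower number from compound 1 to compound 3 (0.50 log units; beyond the scatter) and an at least 3.2-fold lower number from compound 2 to compound 3 (0.50 log units; beyond the scatter), where 4-methylphenyl entered on a saturated chain carbon bound to an oxygen on an aromatic ring and the number fell. A ring of similar size enters in compound 4, so a lower number is expected, of a size like those steps, though the result could remain at the limit. Compound 4 is therefore estimated at 3500 nM, with a range from 1200 nM to 10000 nM. This estimate means an expected step of an at least 2.8-fold lower number from compound 1 to compound 4 (0.45 log units; beyond the scatter).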

Compound 4, half-maximal inhibitory concentration: > 10000 nM
Compound 4 gave a limit, no number; the forecaster's own chance of this, stated with the estimate: 30%; middle value at least 2.8-fold (0.45 log units) from the limit.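

Replacing 4-methylphenyl with cyclohexyl at this position gives an at least 3.2-fold higher number from compound 3 to compound 4 (0.50 log units; beyond the scatter), which shows that the lower number in this assay does not follow from adding just any ring here: the aromatic ring gave a measured value, while the non-aromatic ring of carbon did not. Compound 4 gives > 10000 nM, which is a limit and not a number. The steps to compound 4 from compound 1 and from compound 2 cannot be read, with both ends of each at a limit, and most of the results now sit there: the limit of > 10000 nM in this assay, at which 3 of the 4 values shown sit.

From the compounds shown here alone, how far compounds 1, 2 and 4 lie beyond that limit remains unknown. Going by these compounds, it also remains open whether the methyl of 4-methylphenyl matters, which plain phenyl would test, and how a ring carrying an amine or a carboxylic acid would read.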